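This account rests on a few compounds, and the source may have more. Where it says the series, first, only, none or still open, it means among the compounds named here.

Measured so far:
compound 1 `CC(C)(C)C1=NN(c2ccc(Cl)cc2)C(c2ccc(Cl)cc2)C1` — 11.8%
compound 2 `CC(C)(C)C1=NN(c2ccc(O)cc2)C(c2ccc(O)cc2)C1` — 40.9%

Of the two compounds measured in an assay on isolated protein for inhibition of protein kinase C zeta type (Homo sapiens), with a stated time of 4 min, tested at 62.5 uM (a higher number here means more inhibition at the concentration tested (going by the name of the read-out), a lower number less inhibition), compound 2 gives the higher number, 40.9%, and compound 1 stands clearly lower at 11.8%, a gap beyond the usual scatter. Among the compounds with values here, no single-point step between measured compounds is available; the two differ at both of their outer rings at once.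

Compound 3 `CC(C)(C)C1=NN(c2ccc(O)cc2)C(c2ccc(Cl)cc2)C1` is not yet measured. It differs from compound 2 at one outer ring only: chloro in place of hydroxy on an aromatic carbon. Compound 3 thus sits structurally between compound 2 and compound 1. With compound 2 at 40.9% and compound 1 at 11.8%, compound 3 is expected to fall in between, so a downward step of a number 15.9 percentage points lower from compound 2 to compound 3 (beyond the scatter) is expected, of a size likely beyond the scatter though this rests on two points only. Compound 3 is estimated at 25%, in a range from 10% to 40%.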

Compound 3, a percentage reported as inhibition, at one concentration (the size of the read-out at that concentration, not a potency): 72.2%
Compound 3: the middle estimate sits 47.2 percentage points below what was measured; the whole stated range lies below it.
By their numbers in this assay, from the lowest: compound 1; then compound 2; then compound 3.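

In this assay, chloro in place of hydroxy on one outer ring gives a number 31.3 percentage points higher from compound 2 to compound 3 (beyond the scatter), so with hydroxy on the other outer ring, the number is higher with the 4-chlorophenyl group than with the 4-hydroxyphenyl group. The other single change, hydroxy in place of chloro on the other outer ring, also goes upward, a number 60.4 percentage points higher from compound 1 to compound 3 (beyond the scatter), so compound 3, with one group of each kind, stands above both compounds that carry the same group on both rings, and the two outer rings do not respond alike to these groups. Nothing at hand gives a reason for either rise.

As far as these compounds go, whether the gain depends on chloro itself at this position remains open, as a methoxy group or an amine there would show. Also open, from the compounds shown here alone, is whether the gain needs the hydroxy group on the other ring.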